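Swapping acetyl for dimethylamino on a pyrazole-linked biaryl

The compounds below may be only part of what the source reports. "The series", "measured", "known", "first", "only" and "open" are said of these compounds alone.

Compound 1 `COc1cc(C)cc(-c2c(-c3ccnc(-c4ccc(C(C)=O)cc4)c3)cnn2CC#N)c1` gives 3350 nM in a functional assay on HOP-62 cells (Homo sapiens) for inhibition, read by sulforhodamine B assay, with a stated time of 48 h; a higher number here means a weaker inhibitor of growth, a lower number a stronger inhibitor of growth. That is the highest of the three numbers measured here: compound 2 `COc1cc(C)cc(-c2nn(CC#N)cc2-c2ccc(-c3cccc(C(C)=O)c3)nc2)c1`, with 3070 nM, sits within the scatter of compound 1, while compound 3 `COc1cc(C)cc(-c2nn(CC#N)cc2-c2ccnc(-c3ccc(N(C)C)cc3)c2)c1`, with 390 nM, lies clearly lower, beyond the scatter. Compound 4 `COc1cc(C)cc(-c2c(-c3ccnc(-c4ccc(N(C)C)cc4)c3)cnn2CC#N)c1` differs from compound 1 in a single place: dimethylamino in place of acetyl on an aromatic carbon. Among the compounds with values here, no directly measured pair isolates this change, but compound 3 carries the same dimethylamino group and gives 390 nM. Compound 4 is therefore expected to show a step of a 6.7-fold lower number from compound 1 to compound 4 (0.83 log units; beyond the scatter), toward a lower number. The estimate for compound 4 is 500 nM, within a range of 150 nM to 1600 nM.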

Compound 4, concentration for 50% growth inhibition: 263 nM
Estimate against measurement, compound 4: 1.9-fold (0.28 log units) above; measured number inside the range.
By their numbers in this assay, from the lowest: compounds 4 and 3 (each within the scatter of the next); then compounds 2 and 1 (each within the scatter of the next).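

On the core of compound 1, the exchange of 4-acetylphenyl for 4-(dimethylamino)phenyl now rests on a directly measured pair: in this assay it gives a 13-fold lower number from compound 1 to compound 4 (1.11 log units; beyond the scatter) and counts as a large step. Before this, dimethylamino had been seen only in compound 3, which differs from compound 1 in more than one place, so the change could not be tied to this position alone. Nothing available explains the size of this step.

As far as these compounds go, whether another amine, such as morpholine or pyrrolidine, or a methoxy group would give a similar step at this position remains open. So does whether the same exchange would carry over to the core of compound 2.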